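The source may report more compounds than this note shows. Statements on the series, on what has been measured and on what is new or still open speak of the compounds shown alone.

In a functional assay on HOS-TE85 cells (Homo sapiens) for inhibition, read by CCK-8 assay, with a stated time of 72 h (a higher number here means a weaker inhibitor, a lower number a stronger inhibitor), three compounds have been measured so far. Compound 1 `COc1ccc(C)cc1N1C(=O)CSC1c1cccc(C(=O)NCCCCc2ccccc2)c1` gives 300 nM, the highest number of the three and beyond the usual scatter from both others, which makes it the weakest inhibitor of this small set. Compound 3 `COc1ccccc1N1C(=O)CSC1c1cccc(C(=O)NCCCCc2ccc(Cl)cc2)c1` gives 78.6 nM, and compound 2 `Cc1ccnc(N2C(=O)CS[C@@H]2c2cccc(C(=O)NCCCCn3cccn3)c2)c1` gives 21.9 nM. Compound 4 `COc1ccc(F)cc1N1C(=O)CSC1c1cccc(C(=O)NCCCCc2ccccc2)c1` is still unmeasured. It differs from compound 1 in one place, with fluoro in place of methyl on an aromatic carbon. Among the compounds with values here, no measured pair shows this swap, so only a small move to a lower number, within the scatter, is expected. The expected step is a 1.4-fold lower number from compound 1 to compound 4 (0.13 log units; within the scatter). For compound 4 the estimate is 220 nM, with an expected range of 90 nM to 550 nM.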

Compound 4, half-maximal inhibitory concentration: 8.8 nM
Beside the measured number, compound 4's estimate is 25-fold (1.40 log units) above it, and the stated range ends above it.
By their numbers in this assay, from the lowest: compound 4; then compound 2; then compound 3; then compound 1.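

In this assay, one swap on an aromatic carbon para to a methoxy group, fluoro in place of methyl, gives a 34-fold lower number from compound 1 to compound 4 (1.53 log units; beyond the scatter). Within the data shown here, this is the first pair differing in one place, and it shows that this single position can strongly shift the number. No evidence available here explains the size of this step.

A single pair cannot show whether the step comes from gaining fluoro or losing methyl. On these data alone, how a nitrile or an amine on this carbon would compare also remains open.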